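A few compounds are considered here, and "the series" means these few. Any claim that something is new, unique, unknown or untested is made for them only; others in the source may bear on it.

Compound 1 `Cc1ccc(NC(=S)N/N=C/c2ccc3ccccc3n2)cc1`: 78300 nM
Compound 2 `S=C(N/N=C/c1ccc2ccccc2n1)Nc1ccccc1Br`: > 100000 nM, a limit

In a functional assay on HL-60 cells (Homo sapiens) for antiproliferative activity, read by sulforhodamine B assay, with a stated time of 72 h (on this read-out lower numbers stand for stronger inhibition and higher numbers for weaker inhibition), compound 1 gives 78300 nM. Compound 2 has no exact number, only the limit > 100000 nM. The next molecule, compound 3 `S=C(N/N=C/c1ccc2ccccc2n1)Nc1cccc(Cl)c1`, keeps the shared core and changes one group: 3-chlorophenyl in place of 2-bromophenyl on an amide-type nitrogen. In words, 3-chlorophenyl takes the place of 2-bromophenyl on an amide-type nitrogen. Among the compounds with values here, one measured step bears on this change, an at least 1.2-fold higher number from compound 1 to compound 2 (0.10 log units; that floor lies within the scatter), as it also swapped the group on that nitrogen. That step gives only a floor, and the floor lies within the scatter. No clear effect of changing this group has been shown so far, so no step beyond the scatter is expected in this assay. The expected change is an at least 1.2-fold lower number from compound 2 to compound 3 (0.09 log units; that floor lies within the scatter). Compound 3 is estimated at 80000 nM, with an expected range from 30000 nM to 100000 nM.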

Compound 3, half-maximal inhibitory concentration: 28800 nM
The estimate for compound 3 lay 2.8-fold (0.44 log units) above the measured number, outside the stated range (below it).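

In this assay, the group on the amide-type nitrogen now shows a clear effect: the earlier step gave only a floor within the scatter, whereas this change gives an at least 3.4-fold lower number from compound 2 to compound 3 (0.54 log units; beyond the scatter). The comparison between two exact values points the same way, with 3-chlorophenyl in place of 4-methylphenyl giving a 2.7-fold lower number from compound 1 to compound 3 (0.43 log units; beyond the scatter), so the effect of changing this group does not rest on a limit alone. Compound 2 has a limit rather than an exact number, so the true size of its step remains unknown: the limit of > 100000 nM in this assay, at which 1 of the 3 values shown sits.

The three groups differ both in what the phenyl ring carries and in where it carries it, so these two changes cannot be separated. Going by these compounds, what 3-bromophenyl, or a phenyl ring bearing an amine or a carboxylic acid, would give on this nitrogen also stays open.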